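Chloro in place of methyl on the shared core

A few compounds are considered here, and "the series" means these few. Any claim that something is new, unique, unknown or untested is made for them only; others in the source may bear on it.

Measured compounds:
compound 1 `Cc1ccc2occ(C3N=C(c4ccccc4)SS3)c(=O)c2c1` — 40%
compound 2 `O=c1c(C(=S)Nc2ccccc2)coc2cc(Cl)ccc12` — 55%

In a functional assay on PC-3 cells (Homo sapiens) for inhibition, read by sulforhodamine B assay, with a stated time of 48 h, tested at 100 uM (a lower number here means less inhibition of growth, a higher number more inhibition of growth at the concentration tested), compound 1 gives 40%, the lowest of the two numbers available. Compound 2 gives 55% in this assay, a number higher than that of compound 1 by more than the usual scatter. Among the measured compounds shown here, compound 2 differs from compound 1 in more than one place, so no single structural change is isolated between the two measured compounds; its value shows only that a chloro-bearing analogue of another type reaches a higher number.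

Compound 3 `O=c1c(C2N=C(c3ccccc3)SS2)coc2ccc(Cl)cc12` is the next compound to be measured. Compared with compound 1 it carries chloro in place of methyl on an aromatic carbon. For the measured compounds named here, no measured pair isolates this exchange, so the expected step of a number 6 percentage points higher from compound 1 to compound 3 (within the scatter) is small, leaning upward, and may well stay within the scatter. Compound 3 is therefore expected to give about 46% in this assay, with a range from 26% to 66%.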

Compound 3, percent growth inhibition at one concentration: 62%
Estimate against measurement, compound 3: 16 percentage points below; the range from low to high includes it.
By their numbers in this assay, from the lowest: compound 1; then compounds 2 and 3 (each within the scatter of the next).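

In this assay, among the compounds shown here, chloro in place of methyl on this aromatic carbon, meta to a fused ring and para to a fused ring, gives a number 22 percentage points higher from compound 1 to compound 3 (beyond the scatter), the first comparison that isolates a single change. This position on the shared core is therefore not indifferent to its substituent: an exchange of one heavy atom, with no change in the counted rings, hydrogen-bond donors, hydrogen-bond acceptors or net charge, moves the read-out beyond the scatter. No measurement available here bears on what underlies this step.

Open, from the compounds shown here alone, is how fluoro, methoxy or an amine on this carbon would read, and how a plain hydrogen there would compare. Also open, going by these compounds, is whether the step holds on other carbons of the ring or across a range of concentrations.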